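The source may report more compounds than this note shows. Statements on the series, on what has been measured and on what is new or still open speak of the compounds shown alone.

Measured so far:
Compound 1 `O=C(/C=C/c1cccc(NC(=O)c2ccccc2Cl)c1)c1nc2ccccc2[nH]1` — 4570 nM
Compound 2 `O=C(Nc1cccc(/C=C/C(=O)c2nc3ccccc3[nH]2)c1)c1ccc(Br)cc1` — 7000 nM
Compound 3 `COc1cccc(C(=O)Nc2cccc(/C=C/C(=O)c3nc4ccccc4[nH]3)c2)c1` — 17800 nM

These three values come from a functional assay on MCF7 cells (Homo sapiens) for antiproliferative activity, read by MTT assay, with a stated time of 48 h; on this read-out higher numbers stand for weaker inhibition and lower numbers for stronger inhibition. Compound 3 stands highest of the three: the step of a 3.9-fold higher number from compound 1 to compound 3 (0.59 log units; beyond the scatter) and the step of a 2.5-fold higher number from compound 2 to compound 3 (0.41 log units; beyond the scatter) both lie beyond the scatter, while the step of a 1.5-fold higher number from compound 1 to compound 2 (0.19 log units; within the scatter) does not. All three measured compounds share one core and differ only in the aryl group on the carbonyl carbon.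

Compound 4 `O=C(/C=C/c1cccc(NS(=O)(=O)c2cccc(Cl)c2)c1)c1nc2ccccc2[nH]1` departs from compound 3 in one place: (3-chlorophenyl)sulfonyl in place of (3-methoxyphenyl)carbonyl on a nitrogen on an aromatic ring. Going by the values given here, none of the measured steps touches the carbonyl itself; they only exchange one aryl group for another and gave, at most, modest steps. Among the compounds with values here, the halogenated aryl groups of compound 1 and compound 2 go with lower numbers than the 3-methoxyphenyl of compound 3, which is the only lean the data offer; the swap of carbonyl for sulfonyl has no measured counterpart. A modest move downward in this assay, with wide uncertainty, is therefore expected. Compound 4 is estimated to give 7000 nM, within a range from 2000 nM to 25000 nM, which corresponds to an expected step of a 2.5-fold lower number from compound 3 to compound 4 (0.41 log units; beyond the scatter).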

Compound 4, half-maximal inhibitory concentration: 4160 nM
Estimate against measurement, compound 4: 1.7-fold (0.23 log units) above, within the range that was stated.
By their numbers in this assay, from the lowest: compounds 4, 1 and 2 (each within the scatter of the next); then compound 3.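

Going by these compounds alone, the replacement of the carbonyl by a sulfonyl on the nitrogen is the only change here that touches the carbonyl itself, and activity persists in this assay with a 4.3-fold lower number from compound 3 to compound 4 (0.63 log units; beyond the scatter), although the aryl group changes in the same step. Against the two halogenated carbonyl compounds, the (3-chlorophenyl)sulfonyl group cannot be told apart, with a 1.7-fold lower number from compound 2 to compound 4 (0.23 log units; within the scatter) and a 1.1-fold lower number from compound 1 to compound 4 (0.04 log units; within the scatter) both lying within the scatter, so a sulfonyl in this place is compatible with values like those of (4-bromophenyl)carbonyl and (2-chlorophenyl)carbonyl, and compound 3 alone stands apart. Nothing measured here bears on what lies behind these differences.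

Link and aryl group change together in every comparison with compound 4, so the share of the sulfonyl and the share of the chlorine in the step from compound 3 remain unresolved. Also open, as far as these compounds go, is how the values would respond to a carboxylic acid or an amine on the aryl ring, or to a simple methyl in place of the aryl group on the sulfonyl.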